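Halogen swap on the aryl ring and adenosine receptor binding

This account rests on a few compounds, and the source may have more. Where it says the series, first, only, none or still open, it means among the compounds named here.

Measured compounds:
compound 1 `Cn1c(=O)[nH]c2c(cnn2-c2ccc(Cl)cc2)c1=N`: 37%
compound 2 `Cn1c(=O)[nH]c2c(cnn2-c2ccc(Br)cc2)c1=N`: 34%
compound 3 `Cn1c(=O)[nH]c2c(cnn2-c2cccc(Br)c2)c1=N`: 40%

Of the compounds shown here, three have been tested in an assay on membranes from brain for binding affinity to adenosine receptor A1 (Rattus norvegicus), read by radioligand binding, tested at 20 uM; on this read-out lower numbers stand for less inhibition and higher numbers for more inhibition at the one concentration tested (going by the name of the read-out). Compound 1 and compound 2 share a core and differ only by chloro in place of bromo on an aromatic carbon; this change made a number 3 percentage points higher from compound 2 to compound 1 (within the scatter). Compound 3 has the same atoms as compound 2, joined differently, and the difference between the two cores is not broken down here. Of the three numbers, that of compound 3 stands highest, but its gaps to compound 1 and to compound 2 both lie within the scatter, so no order among them can be claimed.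

Compound 4 `Cn1c(=O)[nH]c2c(cnn2-c2cccc(Cl)c2)c1=N` has not yet been measured. It is related to compound 3 by chloro in place of bromo on an aromatic carbon. This is the same kind of change as that from compound 2 to compound 1, not the same one: there the place was para to a large group, here it is meta to a large group. The step expected from compound 3 to compound 4 is a number 2 percentage points higher from compound 3 to compound 4 (within the scatter), a small one, because a number 3 percentage points higher from compound 2 to compound 1 (within the scatter) stayed within the scatter. Compound 4 is therefore estimated to give 42% in this assay, with a likely range from 30% to 54%.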

Compound 4, a percentage reported as inhibition, at one concentration (the size of the read-out at that concentration, not a potency): 53%
For compound 4 the middle estimate is 11 percentage points below the measured one, and the stated range covers the measured number.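

In this assay, chloro in place of bromo on an aromatic carbon, meta to a large group, gave a number 13 percentage points higher from compound 3 to compound 4 (beyond the scatter). Set beside the same change at the place para to a large group, this step cannot be told apart from the earlier one: the same change on two cores in this assay, a number 3 percentage points higher (within the scatter) from compound 2 to compound 1 and a number 13 percentage points higher (beyond the scatter) from compound 3 to compound 4, 10 percentage points apart, within the scatter of two such steps. Among the compounds shown here, the two pairs therefore give no ground for saying that the change behaves differently from one core to the other, but they do not show that it carries over with a fixed size either, for one step lies within the scatter, the other beyond it, and only two pairs are at hand.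

The compounds shown leave open how a group other than the two halogens, such as a methoxy group, an amine or a carboxylic acid, would read at the same place on the six-membered aromatic ring. Also open, on these data alone, is whether the effects seen here, each the size of the read-out at one concentration, would be stronger or weaker at any other concentration.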